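Chloro in place of methoxy: cytotoxicity notes

This account rests on a few compounds, and the source may have more. Where it says the series, first, only, none or still open, it means among the compounds named here.

In a functional assay on MT4 cells (Homo sapiens) for cytotoxicity (on this read-out lower numbers stand for stronger inhibition and higher numbers for weaker inhibition), compound 1 `N#Cc1c(N)cccc1Sc1ccc(Cl)cc1` gives 113000 nM and also carries chloro. Compound 2 `COc1ccc(S(=O)(=O)c2cccc(N)c2C#N)cc1` is reported only as a limit (> 200000 nM), so it has no exact value. Compound 3 `N#Cc1c(N)cccc1S(=O)(=O)c1ccc(Cl)cc1` has chloro in place of methoxy on an aromatic carbon, para to a large group (chloro in place of methoxy on an aromatic carbon). Among the compounds with values here, no measured step covers this change, and the reading of compound 1 (113000 nM) is the only guide. A small step towards lower numbers in this assay is expected (an at least 1.4-fold lower number from compound 2 to compound 3 (0.15 log units; that floor lies within the scatter)). For compound 3 the expected value is 140000 nM (estimated range 60000 nM to 250000 nM).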

Compound 3, half-maximal inhibitory concentration: > 5000 nM
Compound 3 gave a limit, no number (the forecaster's own chance of this, stated with the estimate: 45%); the middle value is on the limit's open side.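

In this assay compound 2 is only a limit (> 200000 nM). Within the data shown here, compound 3 is also only a limit (> 5000 nM), so no step from compound 2 to compound 3 can be read. As far as these compounds go, whether chloro in place of methoxy shifts cytotoxicity remains open.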